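The source may hold more compounds than are shown below. What is called first, only, known or untested is meant among the compounds shown, and "the series" means these compounds.

In a functional assay on DU-145 cells (Homo sapiens) for inhibition, read by trypan blue exclusion, with a stated time of 96 h (on this read-out lower numbers stand for stronger inhibition of growth and higher numbers for weaker inhibition of growth), compound 1 (`COc1ccccc1/C=C(\C(=O)c1ccc(Cl)cc1)S(=O)(=O)c1ccc(C)cc1`) gives 1000 nM. Compound 2 (`Cc1ccc(S(=O)(=O)/C(=C/c2ccc(N(C)C)cc2)C(=O)c2ccc(Cl)cc2)cc1`) gives > 100000 nM, which is a limit and not a number. Its standing therefore rests only on (the limit of > 100000 nM in this assay, at which 1 of the 2 values shown sits).

The next compound, compound 3 (`COc1ccc(/C=C(\C(=O)c2ccc(Cl)cc2)S(=O)(=O)c2ccc(C)cc2)cc1O`), changes the same place: 3-hydroxy-4-methoxyphenyl in place of 4-(dimethylamino)phenyl on a double-bonded chain carbon bound to a double-bonded chain carbon. The 3-hydroxy-4-methoxyphenyl group thus takes the place of 4-(dimethylamino)phenyl on a double-bonded chain carbon bound to a double-bonded chain carbon.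

For the measured compounds named here, one measured step bears on this change: an at least 100-fold higher number from compound 1 to compound 2 (2.00 log units; beyond the scatter). That step is large and came with 4-(dimethylamino)phenyl in place of 2-methoxyphenyl. Compound 3 no longer carries the 4-(dimethylamino)phenyl group, so a return towards the level of compound 1 at 1000 nM is expected. This rests on a single step, and compound 3 carries a different substituted phenyl from compound 1, so the expectation stays loose. A large move to a lower number, meaning stronger inhibition of growth, is expected in this assay. The estimated step is an at least 66-fold lower number from compound 2 to compound 3 (1.82 log units; beyond the scatter). For compound 3 the estimated value is 1500 nM, with an expected range of 150 nM to 20000 nM.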

Compound 3, concentration for 50% growth inhibition: 1000 nM
Beside the measured number, compound 3's estimate is 1.5-fold (0.18 log units) above it, within the range that was stated.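

In this assay, the position on a double-bonded chain carbon bound to a double-bonded chain carbon now holds two different methoxy-bearing phenyl groups at one level: 3-hydroxy-4-methoxyphenyl in place of 2-methoxyphenyl gives no change at the digits printed from compound 1 to compound 3 (within the scatter). With 3-hydroxy-4-methoxyphenyl in place of 4-(dimethylamino)phenyl, the series shows an at least 100-fold lower number from compound 2 to compound 3 (2.00 log units; beyond the scatter), so the position tolerates more than the single 2-methoxyphenyl group, and among the three compounds shown only the 4-(dimethylamino)phenyl group stands apart. Compound 2 is held only by a limit, which leaves the full size of this step unread: the limit of > 100000 nM in this assay, at which 1 of the 3 values shown sits.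

The compounds shown leave open whether the hydroxy group, the methoxy group or neither sets the level of compound 3, and whether the loss seen with compound 2 follows the amine as such; a plain phenyl group, or a phenyl group bearing a primary amine or a carboxylic acid, at this place would begin to separate these readings. On these data alone, whether the level of compounds 1 and 3 holds when the 4-chlorophenyl ketone or the tolyl sulfone of the shared core changes also remains open.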